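This account rests on a few compounds, and the source may have more. Where it says the series, first, only, none or still open, it means among the compounds named here.

Measured compounds:
- compound 1, `C=CC(=O)N1C(=O)CC(c2ccc(C(=O)OC)cc2)Sc2ccccc21`, 102000 nM
- compound 2, `C=CC(=O)N1C(=O)CC(c2ccccc2Cl)Sc2ccccc21`, 91400 nM
- compound 3, `C=CC(=O)N1C(=O)CC(c2ccccc2)Sc2ccccc21`, 97400 nM

In a functional assay on HL-60 cells (Homo sapiens) for cytotoxicity, read by CCK-8 assay, with a stated time of 24 h (on this read-out lower numbers stand for stronger inhibition and higher numbers for weaker inhibition), compound 2 gives 91400 nM, and this number sits together with those of compound 1 and compound 3, all three within the scatter of one another. Compound 4, `C=CC(=O)N1C(=O)CC(c2ccc(Br)cc2)Sc2ccccc21`, differs from compound 2 in one place: 4-bromophenyl in place of 2-chlorophenyl on a saturated ring carbon. Two measured steps change the same aryl group and so bear on this one: a 1.0-fold lower number from compound 1 to compound 3 (0.02 log units; within the scatter) and a 1.1-fold higher number from compound 2 to compound 3 (0.03 log units; within the scatter), both within the scatter. Swapping the group on this ring carbon has so far left this assay unmoved, so no step beyond the scatter is expected here either. Compound 4 is therefore expected to give 95000 nM, within 60000 nM to 150000 nM, an expected step of a 1.0-fold higher number from compound 2 to compound 4 (0.02 log units; within the scatter).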

Compound 4, half-maximal inhibitory concentration: 126000 nM
Compound 4: the middle estimate sits 1.3-fold (0.12 log units) below what was measured; the range from low to high includes it.
By their numbers in this assay, from the lowest: compounds 2, 3, 1 and 4 (each within the scatter of the next).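

In this assay, 4-bromophenyl on this saturated ring carbon also stays within the scatter of the other aryl groups: a 1.4-fold higher number from compound 2 to compound 4 (0.14 log units; within the scatter), a 1.3-fold higher number from compound 3 to compound 4 (0.11 log units; within the scatter) and a 1.2-fold higher number from compound 1 to compound 4 (0.09 log units; within the scatter). The four compounds now include bromo, chloro, methoxycarbonyl and plain phenyl, and no swap among these aryl groups moves the number beyond the scatter. Nothing measured here offers an explanation for this result.

On these data alone, it remains open whether an aryl ring carrying an amine or a carboxylic acid, or a simple alkyl chain in place of the ring, would move the number. As far as these compounds go, the effect of changing the vinylcarbonyl group is also open.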